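Compound 3 and the Limit of the HEK293 Assay

The source may report more compounds than this note shows. Statements on the series, on what has been measured and on what is new or still open speak of the compounds shown alone.

compound 1 `COc1cccc(CNC(=O)c2nc3ccc(F)c(OCCc4ccccc4)c3c(=O)[nH]2)c1` gives > 20000 nM
compound 2 `Cc1cc(CNC(=O)c2nc3ccc(F)c(OCCc4ccc(C(=O)O)cc4)c3c(=O)[nH]2)ccc1F` gives > 20000 nM

In an ADME assay on HEK293 cells (Homo sapiens) for cytotoxicity, read by resazurin assay, with a stated time of 72 h (a higher number here means that more compound is tolerated, a lower number that less compound is tolerated), compound 2 gives > 20000 nM as a limit of the assay, not as a number. Compound 1 is also a limit, and the limit of > 20000 nM in this assay, at which 2 of the 2 values shown sit, is all that is known so far. Compound 3 `CCc1cccc(CNC(=O)c2nc3ccc(F)c(OCCc4ccc(C(=O)O)cc4)c3c(=O)[nH]2)c1` carries 3-ethylphenyl in place of 4-fluoro-3-methylphenyl on a saturated chain carbon bound to an amide-type nitrogen. For the measured compounds named here, no measured step shows what such an exchange does in this assay, so no step beyond the usual scatter is expected, in either direction. The estimated step of a number no higher from compound 2 to compound 3 (the limit leaves the size open) is therefore a small one. Compound 3 is expected at 20000 nM within a range of 12000 nM to 35000 nM on the same read-out, and it will most likely be reported as a limit again.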

Compound 3, half-maximal cytotoxic concentration: > 20000 nM
Compound 3: only a limit was reported (the forecaster's own chance of this, stated with the estimate: 85%); the middle value sits exactly at the limit.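

In this assay compound 3 gives > 20000 nM, a limit of the assay and not a number. For the compounds shown here, compound 2 also stands at a limit, so no step between compound 2 and compound 3 can be read. The compounds shown leave open what half-maximal cytotoxic concentration any of them would reach, and what 3-ethylphenyl in place of 4-fluoro-3-methylphenyl does in this assay.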